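A dichlorophenyl swap on compound 2

The source may report more compounds than this note shows. Statements on the series, on what has been measured and on what is new or still open speak of the compounds shown alone.

Of the compounds shown here, three have been tested so far in a functional assay on HeLa cells (Homo sapiens) for inhibition, read by CCK-8 assay, with a stated time of 48 h (on this read-out higher numbers stand for weaker inhibition and lower numbers for stronger inhibition), and none has returned a number. Compound 1 (`O=C(Nc1cccc([N+](=O)[O-])c1)N1CCN(S(=O)(=O)c2sccc2-c2ccccc2Oc2ccc(O)c(O)c2)CC1`) gives > 20000 nM here, which is a limit. Compound 3 (`COc1ccc(NC(=S)NCCNS(=O)(=O)c2sccc2-c2ccc(C)cc2Oc2ccc(O)c(O)c2)cc1`) gives > 20000 nM here, again only a limit. Compound 2 (`COc1cccc(NC(=O)NCCNS(=O)(=O)c2ccc(-c3ccccc3OCc3ccccc3)s2)c1`) gives > 50000 nM here, and this too is a limit. Compound 2 therefore has no exact place on the scale, and the other two results offer no number to rank it against.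

The next molecule is compound 4 (`O=C(NCCNS(=O)(=O)c1ccc(-c2ccccc2OCc2ccccc2)s1)Nc1cc(Cl)cc(Cl)c1`), which has not yet been tested. It carries 3,5-dichlorophenyl in place of 3-methoxyphenyl on an amide-type nitrogen. For the measured compounds named here, its single change from compound 2 is 3,5-dichlorophenyl in place of 3-methoxyphenyl on an amide-type nitrogen and the rest of the molecule stays the same. Going by the values given here, no measured pair shows what a swap like this does, so the forecast is rough, and a further limit is the likeliest single outcome. The expected change is an at least 1.6-fold lower number from compound 2 to compound 4 (0.22 log units; that floor lies within the scatter) as a modest estimated move towards stronger inhibition. Compound 4 is expected to come in near 30000 nM with an estimated range from 8000 nM to 80000 nM in this test.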

Compound 4, half-maximal inhibitory concentration: > 20000 nM
Compound 4: no number, only a limit; the forecaster's own chance of this, stated with the estimate: 60%; the middle value is on the limit's open side.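

Compound 2 and compound 4 each return only a limit in this assay, and the step between them cannot be read. The compounds shown leave open whether 3,5-dichlorophenyl in place of 3-methoxyphenyl changes inhibition at all, and what exact value any of the four compounds would reach.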